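Furan to Thiophene on the Amidine-Bearing Carbon

The source may report more compounds than this note shows. Statements on the series, on what has been measured and on what is new or still open speak of the compounds shown alone.

Measured compounds:
compound 1 `c1ccc(C(/N=C2\CCCCCN2)C2CC2)cc1` gives 18%
compound 2 `c1ccc(C(/N=C2\CCCCCN2)c2ccco2)cc1` gives 34%

Both numbers come from a functional assay on the whole organism (plasma, strain Sprague-Dawley) with Rattus norvegicus as the target, with a stated time of 2 h, at a dose of 25 mg/kg by the oral route; on this read-out lower numbers stand for a weaker effect and higher numbers for a stronger effect at the one dose given. Among the compounds with values here, compound 2 stands highest of the two, and the only step measured, a number 16 percentage points higher from compound 1 to compound 2 (beyond the scatter), separates it from compound 1.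

Compound 3 `c1ccc(C(/N=C2\CCCCCN2)c2cccs2)cc1` has not yet been measured. It differs from compound 2 by thiophen-2-yl in place of furan-2-yl on a saturated chain carbon bound to an aromatic carbon and a double-bonded nitrogen. Within the data shown here, no measured step exchanges one five-membered aromatic ring for another; the single step known swaps cyclopropyl for furan-2-yl, so it speaks to that place but not to this particular exchange. Given that the shared core and the place of the change are kept, and that both rings entering and leaving are aromatic and of the same size, a step within the scatter is expected, a number 2 percentage points higher from compound 2 to compound 3 (within the scatter), with the direction uncertain. The value expected for compound 3 is therefore 36%, with a range from 16% to 56%.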

Compound 3, a percentage reported as inhibition, in the whole organism at one dose (the size of the read-out at that dose, not a potency): 36%
Compound 3: the middle estimate sits on the measured number at the digits printed; measured number inside the range.
By their numbers in this assay, from the lowest: compound 1; then compounds 2 and 3 (each within the scatter of the next).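

In this assay, thiophen-2-yl in place of furan-2-yl gives a number 2 percentage points higher from compound 2 to compound 3 (within the scatter), so on the saturated chain carbon bound to an aromatic carbon and a double-bonded nitrogen, the exchange of oxygen for sulfur in the ring leaves the two compounds indistinguishable. Thiophen-2-yl in place of cyclopropyl gives a number 18 percentage points higher from compound 1 to compound 3 (beyond the scatter), so the rise seen with furan-2-yl is repeated by a second five-membered aromatic ring with 1 hetero atom. Nothing available explains why the numbers fall as they do.

The compounds shown leave open whether a plain phenyl ring or pyridin-2-yl at this place would give a number like those of compound 2 and compound 3. They also leave open how an open chain such as n-butyl or a group carrying an amine would compare with cyclopropyl.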